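Halogen swap on the isopropylcarbonyl piperidine series

A few compounds are considered here, and "the series" means these few. Any claim that something is new, unique, unknown or untested is made for them only; others in the source may bear on it.

Compound 1 `CC(=O)N1CCC(C[C@@H](c2nc3cc(F)ccc3n2C)N2C(=O)CN(c3ccc(Oc4ccccc4)cc3)C2=O)CC1` is the reference point of the set. In an assay on cells for antagonist activity at Bile acid receptor (Homo sapiens), read by a luciferase reporter, with a stated time of 24 h (a lower number here means a stronger inhibitor, a higher number a weaker inhibitor), compound 1 gives 1 nM. Compound 2 `CC(=O)N1CCC(C[C@@H](c2nc3ccc(Cl)cc3n2C)N2C(=O)CN(c3ccc(Oc4ccccc4)cc3)C2=O)CC1` carries a change on the shared core, namely (6-chloro-1-methyl-1H-benzimidazol-2-yl in place of 5-fluoro-1-methyl-1H-benzimidazol-2-yl on a saturated chain carbon bound to an amide-type nitrogen in a ring and a saturated chain carbon); in this assay compound 2 gives 0.8 nM, and the step is a 1.3-fold lower number from compound 1 to compound 2 (0.10 log units; within the scatter). Compound 3 `CC(C)C(=O)N1CCC(C[C@@H](c2nc3cc(F)ccc3n2C)N2C(=O)CN(c3ccc(Oc4ccccc4)cc3)C2=O)CC1` keeps the benzimidazole of compound 1 and changes the other end; in this assay compound 3 gives 0.06 nM, the lowest number of the three, reached through a 17-fold lower number from compound 1 to compound 3 (1.22 log units; beyond the scatter). Among the measured compounds shown here, compound 2 and compound 3 have no step recorded against each other; their two values alone show compound 3 with the lower number.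

Compound 4 `CC(C)C(=O)N1CCC(C[C@@H](c2nc3ccc(Cl)cc3n2C)N2C(=O)CN(c3ccc(Oc4ccccc4)cc3)C2=O)CC1` is not yet measured. It differs from compound 3 by 6-chloro-1-methyl-1H-benzimidazol-2-yl in place of 5-fluoro-1-methyl-1H-benzimidazol-2-yl on a saturated chain carbon bound to an amide-type nitrogen in a ring and a saturated chain carbon, the same change as that from compound 1 to compound 2, at the same place. The core of compound 3 and compound 4 differs from that of compound 1 and compound 2 by isopropyl in place of methyl on a carbonyl carbon.

In this assay compound 4 is expected to give 0.05 nM, with the likely range from 0.02 nM to 0.15 nM. The expected step of a 1.2-fold lower number from compound 3 to compound 4 (0.08 log units; within the scatter) is set beside the earlier one because the same change gave a 1.3-fold lower number from compound 1 to compound 2 (0.10 log units; within the scatter), a step within the scatter, so compound 4 is expected to stay close to compound 3.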

Compound 4, half-maximal inhibitory concentration: 0.05 nM
The estimate for compound 4 equals the measured number at the digits printed; measured number inside the range.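

In this assay the halogen swap remains a step within the scatter on the isopropyl core, a 1.2-fold lower number from compound 3 to compound 4 (0.08 log units; within the scatter), and it matches its counterpart on the methyl core: the same change on two cores in this assay, a 1.3-fold lower number (0.10 log units; within the scatter) from compound 1 to compound 2 and a 1.2-fold lower number (0.08 log units; within the scatter) from compound 3 to compound 4, 1.0-fold (0.02 log units) apart, within the scatter of two such steps The isopropyl-for-methyl change on the carbonyl carbon remains large with the 6-chloro-1-methyl-1H-benzimidazol-2-yl group in place, a 16-fold lower number from compound 2 to compound 4 (1.20 log units; beyond the scatter), and it too carries over from one core to the other: the same change on two cores in this assay, a 17-fold lower number (1.22 log units; beyond the scatter) from compound 1 to compound 3 and a 16-fold lower number (1.20 log units; beyond the scatter) from compound 2 to compound 4, 1.0-fold (0.02 log units) apart, within the scatter of two such steps Within these four compounds, each change therefore has about the same size whichever form the other end takes, but this rests on one pair of steps per change and does not show that either would carry over to a core outside this set.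

The swap changes both the halogen and its place in the name of the group, so 6-fluoro-1-methyl-1H-benzimidazol-2-yl and 5-chloro-1-methyl-1H-benzimidazol-2-yl would be needed to separate the two, and the compounds shown do not settle which of them, if either, matters. Also open, going by these compounds, is whether the large step seen with isopropyl extends to a tert-butyl, a cyclopropyl or a longer chain on the carbonyl carbon.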